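The compounds below may be only part of what the source reports. "The series", "measured", "known", "first", "only" and "open" are said of these compounds alone.

Measured so far:
Compound 2 `C=C1C(=O)O[C@H]2[C@H]1CC/C(COC(=O)Cn1cc(F)c(=O)n(Cc3ccc(F)cc3)c1=O)=C\CC[C@@]1(C)O[C@@H]21`: in a functional assay on Bel-7402 cells (Homo sapiens) for antiproliferative activity, read by MTT assay, with a stated time of 72 h (a higher number here means a weaker inhibitor, a lower number a stronger inhibitor), compound 2 gives 2730 nM.
Compound 1 `C=C1C(=O)O[C@H]2[C@H]1CC/C(COC(=O)CCC(=O)N1CCN(C(=O)Cn3cc(F)c(=O)n(Cc4ccccc4)c3=O)CC1)=C\CC[C@@]1(C)O[C@@H]21`: in this assay compound 1 gives a limit, > 20000 nM.

Going by the values given here, compound 2 carries the only actual number among the two. Among the compounds with values here, for compound 1 the read-out stops at a limit (the limit of > 20000 nM in this assay, at which 1 of the 2 values shown sits), so it cannot be ranked against compound 2 and no measured step connects them. The step that matters here runs from compound 2 to the still unmeasured compound 3 `C=C1C(=O)O[C@H]2[C@H]1CC/C(COC(=O)Cn1cc(F)c(=O)n(C)c1=O)=C\CC[C@@]1(C)O[C@@H]21`. The two share the whole core and the ester-linked fluorinated pyrimidine; the only difference is hydrogen in place of 4-fluorophenyl on a saturated chain carbon bound to an aromatic nitrogen. In the larger compound 1, which also carries a benzyl on that nitrogen but a much longer linker, activity was not reached, so the benzyl group alone does not guarantee potency, and the core itself seems to carry much of the effect. Still, dropping the aromatic group is expected to cost some activity: the step of a 1.8-fold higher number from compound 2 to compound 3 (0.26 log units; within the scatter) is expected to be a modest weakening, near the edge of the usual scatter. Compound 3 is therefore estimated at 5000 nM, with a plausible range from 1500 nM to 20000 nM.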

Compound 3, half-maximal inhibitory concentration: 9400 nM
Compound 3: the middle estimate sits 1.9-fold (0.27 log units) below what was measured; measured number inside the range.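

Replacing the 4-fluorophenyl with hydrogen on this saturated chain carbon gives a 3.4-fold higher number from compound 2 to compound 3 (0.54 log units; beyond the scatter) in this assay, the first measured sign that the group at this place affects the read-out. The loss is modest: compound 3 still gives a measured 9400 nM, so among these compounds the aromatic ring is not needed for a number to be obtained in this assay, although compound 2, which has the ring, gives the lower number. Compound 1 stays at a limit, has a different linker as well, and so adds nothing to this comparison: the limit of > 20000 nM in this assay, at which 1 of the 3 values shown sits.

From the compounds shown here alone, what remains open is whether the difference between compound 2 and compound 3 follows the aromatic ring, the fluorine on it, or simply the size of the group, since the change removes all of these at once. A chain such as propyl, a cyclohexyl ring or an amine at the end of a short chain in the same place would help to separate these possibilities.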